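This account rests on a few compounds, and the source may have more. Where it says the series, first, only, none or still open, it means among the compounds named here.

Measured compounds:
- compound 1, `O=c1[nH]c(=O)n([C@@H]2O[C@@H]3COP(=O)(O)O[C@H]3[C@H]2O)cc1F`, in a functional assay on Raji cells (Homo sapiens); on this read-out lower numbers stand for stronger inhibition and higher numbers for weaker inhibition: 1.64 ug/mL
- compound 2, `O=c1[nH]c(=O)n([C@@H]2O[C@H](COP(=O)(O)O)[C@@H](O)[C@H]2O)cc1I`: in this assay compound 2 gives > 1000 ug/mL, which is a limit of the assay and not a number.

Compound 1 is thus the only compound with a number shown in this assay; the other reading, (the limit of > 1000 ug/mL in this assay, at which 1 of the 2 values shown sits), is a limit. Within the data shown here, compound 2 differs from compound 1 in more than one place, so the two values show only that one is a number and one a limit.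

Compound 3, `O=c1[nH]c(=O)n([C@@H]2O[C@@H]3COP(=O)(O)O[C@H]3[C@H]2O)cc1Cl`, has not yet been measured. It differs from compound 1 by chloro in place of fluoro on an aromatic carbon; the shared core otherwise stays the same. No measured step of this kind exists among the compounds shown, so the effect of chloro in place of fluoro must be estimated. Compound 3 is expected to be a somewhat weaker inhibitor than compound 1, with a step of a 6.1-fold higher number from compound 1 to compound 3 (0.79 log units; beyond the scatter) in this assay. Compound 3 is therefore estimated at 10 ug/mL, within a range from 2 ug/mL to 60 ug/mL.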

Compound 3, concentration for 50% inhibition: 369 ug/mL
Estimate against measurement, compound 3: 37-fold (1.57 log units) below; measured number outside the range, above it.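

Within this assay this position proves highly sensitive to the identity of the halogen, with chloro in place of fluoro on an aromatic carbon giving a 230-fold higher number from compound 1 to compound 3 (2.35 log units; beyond the scatter) on an otherwise unchanged core. Neither group brings a ring, a hydrogen-bond donor or acceptor, or a net charge, and each counts a single heavy atom, yet this one exchange separates the two compounds far beyond the scatter. Among these compounds, compound 2 gives a limit and not a number, and it differs from compound 1 in more than one place, which leaves this single step as the only comparison that can be read: the limit of > 1000 ug/mL in this assay, at which 1 of the 3 values shown sits.

What lies behind the size of the step remains unknown, as one step at one position gives no trend. As far as these compounds go, whether hydrogen, bromo, methyl or an amine on this carbon would stand nearer compound 1 or compound 3 also remains open.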